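Urea to amide with an added chloro substituent

A few compounds are considered here, and "the series" means these few. Any claim that something is new, unique, unknown or untested is made for them only; others in the source may bear on it.

Compound 1 `COc1cc(-c2nn(-c3cccc(NC(=O)c4cccc(C(F)(F)F)c4)c3)cc2-c2ccncc2)ccc1Cl`: 1020 nM
Compound 2 `COc1cc(-c2nn(-c3cccc(NC(=O)Nc4ccc(Cl)c(Cl)c4)c3)cc2-c2ccncc2)ccc1Cl`: 691 nM
Compound 3 `COc1cc(-c2nn(-c3cccc(NC(=O)Nc4cccc(C(F)(F)F)c4)c3)cc2-c2ccncc2)ccc1Cl`: 306 nM

In a functional assay on SF-295 cells (Homo sapiens) for inhibition, read by sulforhodamine B assay, with a stated time of 48 h (a higher number here means a weaker inhibitor of growth, a lower number a stronger inhibitor of growth), compound 3 gives the lowest number of the three. The change from compound 1 to compound 3 was a 3.3-fold lower number from compound 1 to compound 3 (0.52 log units; beyond the scatter), and from compound 2 to compound 3 it was a 2.3-fold lower number from compound 2 to compound 3 (0.35 log units; beyond the scatter), while a 1.5-fold lower number from compound 1 to compound 2 (0.17 log units; within the scatter) stayed within scatter. Compound 4 `COc1cc(-c2nn(-c3cccc(NC(=O)c4ccc(Cl)c(C(F)(F)F)c4)c3)cc2-c2ccncc2)ccc1Cl` differs from compound 3 by 4-chloro-3-(trifluoromethyl)phenyl in place of (3-(trifluoromethyl)phenyl)amino on a carbonyl carbon. This reverses the step that set compound 3 apart from compound 1, so a rise back toward the value of compound 1 1020 nM is expected. Compound 4 is therefore estimated at 900 nM (range 350 nM to 2500 nM) in this assay, an expected step of a 2.9-fold higher number from compound 3 to compound 4 (0.47 log units; beyond the scatter).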

Compound 4, concentration for 50% growth inhibition: 1380 nM
Compound 4: middle estimate off by 1.5-fold (0.19 log units), on the low side; the range from low to high includes it.
By their numbers in this assay, from the lowest: compound 3; then compounds 2, 1 and 4 (each within the scatter of the next).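

In this assay, putting 4-chloro-3-(trifluoromethyl)phenyl in place of (3-(trifluoromethyl)phenyl)amino on the carbonyl carbon gives a 4.5-fold higher number from compound 3 to compound 4 (0.65 log units; beyond the scatter), so the urea compound 3 also stays ahead of this chlorinated amide. Chloro in place of hydrogen on the amide's aromatic ring gives a 1.4-fold higher number from compound 1 to compound 4 (0.13 log units; within the scatter) and the step from the dichlorophenyl urea gives a 2.0-fold higher number from compound 2 to compound 4 (0.30 log units; within the scatter), and both lie within the scatter. Nothing measured here explains these steps. Going by these compounds, whether fluoro or methoxy at that ring carbon would match chloro remains open.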